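The source may report more compounds than this note shows. Statements on the series, on what has been measured and on what is new or still open speak of the compounds shown alone.

In a functional assay (Homo sapiens) (a lower number here means a stronger inhibitor, a higher number a weaker inhibitor), three compounds sharing one core have been measured. Compound 1 `Nc1nc2ccnc(-c3cccc(C(Cl)Cl)c3)n2n1` gives 1000 nM, and compound 3 `Cc1ccc(S(=O)(=O)Nc2cccc(-c3nccc4nc(N)nn34)c2)cc1` gives 1500 nM. Compound 2 `Nc1nc2ccnc(-c3ccc(F)cc3)n2n1` gives 31300 nM, the highest number of the three and so the weakest inhibitor among them, with a gap beyond the scatter to each of the others. Compound 4 `CCOC(=O)c1ccc(-c2nccc3nc(N)nn23)cc1` has not been measured yet. It differs from compound 2 by a single change: ethoxycarbonyl in place of fluoro on an aromatic carbon. In words, ethoxycarbonyl stands in place of fluoro on an aromatic carbon, para to a large group. Among the measured compounds shown here, no measured pair shows this swap on its own, so the guide is loose. Compound 1 at 1000 nM and compound 3 at 1500 nM both carry larger groups than the fluoro of compound 2, and three compounds are too few to call this a rule. A drop beyond the scatter is still expected, and the estimated step is a 5.2-fold lower number from compound 2 to compound 4 (0.72 log units; beyond the scatter). For compound 4 the expected value is 6000 nM, within an estimated range of 1500 nM to 25000 nM.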

Compound 4, half-maximal inhibitory concentration: 16500 nM
Estimate against measurement, compound 4: 2.8-fold (0.44 log units) below; low and high end bracket the measured number.
By their numbers in this assay, from the lowest: compounds 1 and 3 (each within the scatter of the next); then compounds 4 and 2 (each within the scatter of the next).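

In this assay, putting ethoxycarbonyl in place of fluoro on this aromatic carbon, para to a large group, gives a 1.9-fold lower number from compound 2 to compound 4 (0.28 log units; within the scatter) and so leaves the two compounds indistinguishable in this measurement. Among the compounds shown here, this is the first direct look at this position, and it shows that a much larger group carrying hydrogen-bond acceptors, which fluoro lacks, can sit here without a change beyond the scatter. Nothing available explains why the swap has so little effect.

From the compounds shown here alone, whether a carboxylic acid or an amine on this same carbon would shift the number beyond the scatter remains open. Compounds 1 and 3 differ from compound 4 in more than one place, so what sets them apart from it also remains unresolved.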